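The source may report more compounds than this note shows. Statements on the series, on what has been measured and on what is new or still open speak of the compounds shown alone.

Of the compounds shown here, three built on one shared core have been tested in a functional assay on the whole organism (strain Wistar albino) for inhibition, with Rattus norvegicus as the target, read by paw edema, with stated times of 30 min and 2 h, at a dose of 10 mg/kg by the oral route; on this read-out higher numbers stand for more inhibition at the one dose given (going by the name of the read-out) and lower numbers for less inhibition. Compound 1 `COc1ccc(F)cc1-c1cccc(-c2nn(CCCC#N)c(=O)o2)c1` gives 71%. Compound 2 `COc1ccc(F)cc1-c1cccc(-c2n[nH]c(=O)o2)c1` gives 56%. Compound 3 `COc1ccc(F)cc1-c1cccc(-c2nn(CCOC3CCCCO3)c(=O)o2)c1` gives 56%. Compound 3 thus stands level with compound 2 to the digit reported, and the two together hold the lowest numbers of the three, with compound 1 the furthest away and higher.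

Compound 4 `COc1ccc(F)cc1-c1cccc(-c2nn(CCCN)c(=O)o2)c1` has not yet been measured. It differs from compound 3 in a single place: aminomethyl in place of (oxan-2-yl)oxy on a saturated chain carbon, two bonds along the chain from an aromatic nitrogen.

For the measured compounds named here, two measured steps bear on this change. Swapping the group on the chain carbon, a number 15 percentage points lower from compound 1 to compound 3 (beyond the scatter), was a modest loss. Attaching the whole chain to the bare ring nitrogen, no change at the digits printed from compound 2 to compound 3 (within the scatter), made no difference beyond the scatter. Changes at this spot have therefore ranged from none to a modest shift, and a much smaller group now enters, so the step of a number 4 percentage points higher from compound 3 to compound 4 (within the scatter) is expected to stay small and most likely slightly upward. For compound 4 the expected value in this assay is 60%, with a range from 45% to 75%.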

Compound 4, a percentage reported as inhibition, in the whole organism at one dose (the size of the read-out at that dose, not a potency): 66%
Estimate against measurement, compound 4: 6 percentage points below; the measured number falls inside the stated range.
By their numbers in this assay, from the lowest: compounds 2, 3, 4 and 1 (each within the scatter of the next, the first and the last beyond it).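

In this assay, aminomethyl, which has no ring, can stand in place of the much larger (oxan-2-yl)oxy on the chain without a shift beyond the scatter: a number 10 percentage points higher from compound 3 to compound 4 (within the scatter). Attaching 3-aminopropyl to the bare ring nitrogen gives a number 10 percentage points higher from compound 2 to compound 4 (within the scatter), and amino in place of cyano on the chain gives a number 5 percentage points lower from compound 1 to compound 4 (within the scatter), so compound 4 sits within the scatter of all three earlier compounds and does not fall clearly with either compound 1 or the pair of compound 2 and compound 3. Nothing measured here explains these numbers.

Going by these compounds, whether a carboxylic acid in place of the amino group, or a longer chain carrying the amine, would move the number beyond the scatter stays open. With one dose, these numbers also give the size of the effect at that dose, not a potency.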